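The source may hold more compounds than are shown below. What is called first, only, known or untested is meant among the compounds shown, and "the series" means these compounds.

Among the measured compounds shown here, compound 1 `COc1ccc(-c2[nH]c3ccccc3c2/C=C(\C#N)S(=O)(=O)c2ccccc2)cc1` is the only member of this small set with a number in a functional assay on RXF 393 cells (Homo sapiens) for inhibition, read by sulforhodamine B assay, with a stated time of 48 h (a lower number here means a stronger inhibitor of growth, a higher number a weaker inhibitor of growth), where compound 1 gives 1000 nM. Compound 2 `COc1ccc2[nH]c(-c3ccccc3)c(/C=C(\C#N)S(=O)(=O)c3ccccc3)c2c1` carries the methoxy on a different ring, and in this assay compound 2 is recorded as "not determined" (no result reported), so it stands nowhere on the numbers. Compound 3 `N#C/C(=C\c1c(-c2ccccc2)[nH]c2ccccc12)S(=O)(=O)c1ccccc1` differs from compound 2 by hydrogen in place of methoxy on an aromatic carbon. For the measured compounds named here, with no measured pair to anchor the step, nothing beyond the usual scatter is expected in this assay in either direction. Compound 3 is therefore estimated at 1500 nM, within 300 nM to 8000 nM.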

Compound 3, concentration for 50% growth inhibition: 3600 nM
The estimate for compound 3 lay 2.4-fold (0.38 log units) below the measured number; the measured number falls inside the stated range.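

In this assay there is a 3.6-fold higher number from compound 1 to compound 3 (0.56 log units; beyond the scatter) when hydrogen takes the place of the methoxy of compound 1, so on this one pair the methoxy goes with stronger growth inhibition. The step to compound 3 from compound 2 cannot be read, since compound 2 has no number. No measurement here explains the change. 

Among the compounds shown here, still open is whether a methoxy on the ring of compound 2 would count the same way as the one on compound 1. Also open, on these data alone, is how an amine or a chlorine would compare with methoxy and hydrogen at either place.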